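Cytotoxicity notes: methyl for methoxy on compound 3

The compounds below may be only part of what the source reports. "The series", "measured", "known", "first", "only" and "open" are said of these compounds alone.

Three members of the series have been checked in an ADME assay on HeLa cells (Homo sapiens) for cytotoxicity; on this read-out higher numbers stand for lower toxicity in this test and lower numbers for higher toxicity in this test. Compound 1 `CCN(CC)CN1C(=O)/C(=N/NC(=S)Nc2ccccc2)c2cc(Cl)ccc21` in this assay gives only a limit, >= 20000 nM, the limit recorded as the limit of >= 20000 nM in this assay, at which 1 of the 3 values shown sits. Compound 2 `CCN(CC)CN1C(=O)/C(=N/NC(N)=S)c2cc(Cl)ccc21` carries hydrogen in place of phenyl on an amide-type nitrogen; compound 2 also reaches only a limit, > 100000 nM, which is the limit of > 100000 nM in this assay, at which 1 of the 3 values shown sits. Within the data shown here, the one measured step, a step that the two limits leave unreadable from compound 1 to compound 2, is therefore not readable. Compound 3 `CCN(CC)CN1C(=O)/C(=N/NC(=S)Nc2ccc(OC)cc2)c2ccccc21` likewise stands at a limit in this assay: compound 3 gives >= 4000 nM, noted as the limit of >= 4000 nM in this assay, at which 1 of the 3 values shown sits. None of the three values is a number, so compound 3 is placed only by its limit, with no ordering among the three possible.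

Compound 4 `CCN(CC)CN1C(=O)/C(=N/NC(=S)Nc2ccc(C)cc2)c2ccccc21` differs from compound 3 by methyl in place of methoxy on an aromatic carbon. Among the measured compounds shown here, no measured step touches this position; the single step on record concerns another part of the molecule and is unreadable. No step beyond the usual scatter is therefore expected in this assay, and the step from compound 3 to compound 4 is estimated as a step that the limit leaves unreadable from compound 3 to compound 4. Compound 4 is expected to give 6000 nM, between 2000 nM and 40000 nM, most likely again reported only as a limit.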

Compound 4, minimum cytotoxic concentration: >= 20000 nM
Compound 4: only a limit was reported; the forecaster's own chance of this, stated with the estimate: 70%; middle value at least 3.3-fold (0.52 log units) away from the limit.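

In this assay, compound 3 and compound 4 are both recorded only as limits, and no step can be read between them. The compounds shown leave open whether methyl in place of methoxy on the aromatic carbon shifts the minimum cytotoxic concentration at all, and how the four compounds order on this read-out.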